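This account rests on a few compounds, and the source may have more. Where it says the series, first, only, none or still open, it means among the compounds named here.

Compound 1 `CCCCCCCCCCc1ccc(-c2noc(CCCNC)n2)cc1` has the highest of the three numbers in an assay on HeLa cells for inhibition of sphingosine-1-phosphate transporter SPNS2 (Mus musculus), read by LC-MS, tested at 2 uM (a lower number here means less inhibition, a higher number more inhibition at the concentration tested (going by the name of the read-out)), giving 45%, with compound 3 within the scatter of it. Compound 2 `CCCCCCCCCCc1ccc(-c2noc([C@@H]3CCCN3)n2)cc1` gives 21% and compound 3 `CCCCCCCCCCc1ccc(-c2noc([C@@H]3CC[C@H](N)C3)n2)cc1` gives 38%. The step of a number 24 percentage points lower from compound 1 to compound 2 (beyond the scatter) is the only clear one; a number 7 percentage points lower from compound 1 to compound 3 (within the scatter) stays within the scatter, and a number 17 percentage points higher from compound 2 to compound 3 (beyond the scatter) runs the other way. Compound 4 `CCCCCCCCCCc1ccc(-c2noc([C@@H](N)CCCN)n2)cc1` differs from compound 1 by 1,4-diaminobutyl in place of 3-(methylamino)propyl on an aromatic carbon. Both earlier changes at this position lowered the number, one modestly and one only within the scatter, and both brought in a ring where the new group keeps an open chain. The step of a number 5 percentage points lower from compound 1 to compound 4 (within the scatter) is therefore expected to be small or none beyond the scatter. For compound 4 the estimate is 40%, ranging from 20% to 60%.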

Compound 4, a percentage reported as inhibition, at one concentration (the size of the read-out at that concentration, not a potency): 40%
The estimate for compound 4 equals the measured number at the digits printed; the measured number falls inside the stated range.
By their numbers in this assay, from the lowest: compound 2; then compounds 3, 4 and 1 (each within the scatter of the next).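

In this assay, replacing 3-(methylamino)propyl with 1,4-diaminobutyl, an open chain with a defined stereocentre and a second nitrogen, gives a number 5 percentage points lower from compound 1 to compound 4 (within the scatter), so this position accepts that larger chain. Among these compounds, the new group also gives a number 2 percentage points higher from compound 3 to compound 4 (within the scatter) and a number 19 percentage points higher from compound 2 to compound 4 (beyond the scatter), leaving pyrrolidin-2-yl as the one group apart, while the ring of compound 3 shows that rings as such do not separate from open chains here. Nothing measured accounts for these numbers. The compounds shown leave open whether a carboxylic acid or an amide could replace the amine at this position, and whether a longer chain bearing one amine would fit.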